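Replacing the Bromophenyl of Compound 2 with Furan

The source may report more compounds than this note shows. Statements on the series, on what has been measured and on what is new or still open speak of the compounds shown alone.

Measured compounds:
Compound 1, `COc1cc(-c2cccc3nc(-c4ccc(F)cc4)oc23)cc(OC)c1OC`: in a functional assay on U-251 cells (Homo sapiens) for antiproliferative activity, read by MTT assay, with a stated time of 48 h (on this read-out lower numbers stand for stronger inhibition and higher numbers for weaker inhibition), compound 1 gives > 25000 nM, which is a limit of the assay and not a number.
Compound 2, `COc1cc(-c2cccc3nc(-c4cccc(Br)c4)oc23)cc(OC)c1OC`: compound 2 gives 6800 nM.
Compound 3, `COc1cc(-c2cccc3nc(-c4cccc(O)c4)oc23)cc(OC)c1OC`: compound 3 gives 5500 nM.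

Compound 2 holds the higher of the two numbers shown; its nearest neighbor is compound 3, and the gap a 1.2-fold lower number from compound 2 to compound 3 (0.09 log units; within the scatter) lies within the scatter, so the two cannot be told apart. Compound 4, `COc1cc(-c2cccc3nc(-c4ccco4)oc23)cc(OC)c1OC`, differs from compound 2 by furan-2-yl in place of 3-bromophenyl on an aromatic carbon.

For the measured compounds named here, no measured step exchanges a six-membered ring for a five-membered one at this position. The steps that alter this group, an at least 3.6-fold lower number from compound 1 to compound 2 (0.56 log units; beyond the scatter) and an at least 4.5-fold lower number from compound 1 to compound 3 (0.65 log units; beyond the scatter), both start from the limit of > 25000 nM in this assay, at which 1 of the 3 values shown sits, and show that changes here can move the read-out well beyond the scatter. The exchange of bromo for hydroxy, a 1.2-fold lower number from compound 2 to compound 3 (0.09 log units; within the scatter), hardly moved it. With a smaller ring of a different type entering, a step beyond the scatter in either direction is possible, and a somewhat weaker result is expected. The expected step is a 1.3-fold higher number from compound 2 to compound 4 (0.12 log units; within the scatter). Compound 4 is estimated at 9000 nM, in a range from 3000 nM to 30000 nM.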

Compound 4, half-maximal inhibitory concentration: 10600 nM
Compound 4: middle estimate off by 1.2-fold (0.07 log units), on the low side; the measured number falls inside the stated range.
By their numbers in this assay, from the lowest: compounds 3, 2 and 4 (each within the scatter of the next). At a limit, above all of these: compound 1.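

In this assay, a five-membered furan-2-yl ring on this carbon cannot be told apart from either six-membered ring that it replaces: a 1.6-fold higher number from compound 2 to compound 4 (0.19 log units; within the scatter), and a 1.9-fold higher number from compound 3 to compound 4 (0.28 log units; within the scatter). The entering ring is smaller than 3-bromophenyl and, unlike it, carries a hydrogen-bond acceptor, yet the read-out stays within the scatter, so these compounds show no measurable effect of this exchange. The 4-fluorophenyl group alone stands apart, an at least 2.3-fold lower number from compound 1 to compound 4 (0.37 log units; beyond the scatter), and that starting value is a limit of the assay and not a number: the limit of > 25000 nM in this assay, at which 1 of the 4 values shown sits.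

All the groups shown at this position are aromatic rings, so what an amine, a carboxylic acid or a longer alkyl chain would do on this carbon remains open. Also open, as far as these compounds go, is whether the result depends on how the furan is attached, which furan-3-yl would test, and whether 4-fluorophenyl stands apart through the fluorine itself or through where it sits on the ring, which 3-fluorophenyl would help to separate.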